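Methoxy in place of a selenium group on compound 3

The source may report more compounds than this note shows. Statements on the series, on what has been measured and on what is new or still open speak of the compounds shown alone.

Compound 1 `COc1ccc(CNc2nc([SeH])nc3ccccc23)cc1`: in an ADME assay on 184B5 cells (Homo sapiens) for cytotoxicity, read by MTT assay, with a stated time of 72 h (on this read-out higher numbers stand for weaker inhibition of growth and lower numbers for stronger inhibition of growth), compound 1 reaches only the limit of the assay, > 100000 nM.
Compound 2 `CCCCCSc1nc(NCc2ccc([Se]C)cc2)c2ccccc2n1`: in this assay compound 2 likewise gives only the limit, > 100000 nM.
Compound 3 `CSc1nc(NCc2ccc([Se]C)cc2)c2ccccc2n1`: in this assay compound 3 gives only the limit, > 100000 nM.

Compound 3 thus stands at the limit of this assay, the point at which every measured value sits (the limit of > 100000 nM in this assay, at which 3 of the 3 values shown sit). Among the compounds with values here, the single computed step among the measured compounds, a step that the two limits leave unreadable from compound 2 to compound 3, cannot be read, since both of its ends are limits. Compound 4 `COc1ccc(CNc2nc(SC)nc3ccccc23)cc1` differs from compound 3 by a group of 2 heavy atoms (1 carbon, 1 oxygen; no ring) in place of a group of 2 heavy atoms (1 carbon, 1 selenium; no ring), on an aromatic carbon. Compound 1 also carries a methoxy group, yet its reading in this assay is a limit as well, so it adds nothing readable about this exchange. Within the data shown here, no measured step bears directly on the change from compound 3 to compound 4, and with all values at the limit of > 100000 nM in this assay, at which 3 of the 3 values shown sit, no step beyond the scatter can be read in either direction. Compound 4 is accordingly expected to show no measurable inhibition of growth in this assay. Compound 4 is estimated at 150000 nM, with a range from 70000 nM to 500000 nM. The step this estimate implies, a step that the limit leaves unreadable from compound 3 to compound 4, is expected to lie within the scatter, most likely reported once more as a limit.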

Compound 4, concentration for total growth inhibition: > 100000 nM
Compound 4: only a limit was reported (the forecaster's own chance of this, stated with the estimate: 85%); the middle value does not contradict the limit.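

Compound 4 also gives only a limit in this assay, so the steps to it from compound 3 and from compound 1 cannot be read, as each joins two limits: the limit of > 100000 nM in this assay, at which 4 of the 4 values shown sit. The compounds shown leave open how strongly any of them inhibits growth, and whether exchanging the selenium group for methoxy alters that at all.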